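The compounds below may be only part of what the source reports. "The series", "measured", "known", "first", "only" and "open" are said of these compounds alone.

Measured compounds in this series:

compound 1 `O=C(CN(c1ncnc2c1ncn2C1CCCCO1)C1CC1)N[C@@H](CO)C(=O)OCc1ccccc1` — 18.3%
compound 2 `CSCC[C@H](NC(=O)CN(c1nc(Cl)nc2[nH]cnc12)C1CC1)C(=O)OCc1ccccc1` — 17.6%
compound 3 `CC[C@H](C)[C@H](NC(=O)CN(c1ncnc2c1ncn2C1CCCCO1)C1CC1)C(=O)OCc1ccccc1` — 16.4%

All three share a glycinamide spacer carrying a cyclopropyl group and an amino-acid benzyl ester, and all three were run in a functional assay on the whole organism (Tail, strain ICR) with Mus musculus as the target, in the tail flick test, with a stated time of 150 min, at a dose of 25 umol/kg by the oral route; on this read-out lower numbers stand for a weaker effect and higher numbers for a stronger effect at the one dose given. Compound 2 gives 17.6% in this assay, a number that lies within the scatter of both compound 1 and compound 3, so none of the three can be told apart on this read-out.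

The next compound is compound 4 `CC(C)C[C@H](NC(=O)CN(c1nc(Cl)nc2[nH]cnc12)C1CC1)C(=O)OCc1ccccc1`. Relative to compound 2 the change is isopropyl in place of (methylsulfanyl)methyl on a saturated chain carbon, two bonds along the chain from an amide-type nitrogen and a carbonyl carbon. Going by the values given here, the only measured step that speaks to a side-chain swap on the amino-acid carbon is a number 1.9 percentage points lower from compound 1 to compound 3 (within the scatter), where sec-butyl replaced hydroxymethyl without moving the number beyond the scatter. That step sits on a different core than compound 2 and compound 4, and the groups exchanged are not the same, so it is a loose guide. Among the compounds with values here, still, it is the one piece of evidence and it shows nothing beyond scatter for a side-chain change of this kind. No step beyond the scatter is therefore expected in this assay; the step from compound 2 to compound 4 is estimated at a number 0.1 percentage points lower from compound 2 to compound 4 (within the scatter). Compound 4 is expected to give 17.5%, with a range from 8% to 27%.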

Compound 4, a percentage reported as activity, at one dose (the size of the read-out at that dose, not a potency): 5.26%
The estimate for compound 4 lay 12.2 percentage points above the measured number, and the stated range ends above it.
By their numbers in this assay, from the lowest: compound 4; then compounds 3, 2 and 1 (each within the scatter of the next).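

In this assay, going by these compounds alone, the side chain on this carbon is the first place where a single change goes beyond the scatter: the number falls a number 12.3 percentage points lower from compound 2 to compound 4 (beyond the scatter) on exchanging (methylsulfanyl)methyl for isopropyl, on a saturated chain carbon, two bonds along the chain from an amide-type nitrogen and a carbonyl carbon. The earlier step, a number 1.9 percentage points lower from compound 1 to compound 3 (within the scatter) for sec-butyl in place of hydroxymethyl, sits on the core of compound 1 and on a saturated chain carbon bound to an amide-type nitrogen and a carbonyl carbon, so it does not describe this change, and the flat picture from the first three compounds does not hold for the core of compound 2. The swap leaves the heavy-atom count as it stands, and what differs is sulfur against carbon, one hydrogen-bond acceptor leaving, and the branched isopropyl against an unbranched group.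

Nothing shown here explains the fall in the number. Still open, going by these compounds, is whether a straight-chain n-propyl or a methoxymethyl group on the same carbon would stay with compound 2 or fall with compound 4, which would separate the sulfur from the branching.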